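The compounds below may be only part of what the source reports. "The series", "measured", "known", "first", "only" and "open" are said of these compounds alone.

Measured so far:
compound 1 `O=C(Nc1ccc(Cl)cc1)NS(=O)(=O)c1cccs1` — 66%
compound 2 `O=C(Nc1ccc(Cl)cc1)NS(=O)(=O)c1ccc(Cl)s1` — 89%

Both numbers come from a functional assay on the whole organism (6C3HED cells, Mus musculus) for inhibition, at a dose of 300 mg/kg by the oral route; a higher number here means more inhibition at the dose given (going by the name of the read-out), a lower number less inhibition. Compound 2 stands highest of the two; its nearest neighbour is compound 1, a number 23 percentage points higher from compound 1 to compound 2 (beyond the scatter), beyond the scatter. Compound 3 `COc1ccc(S(=O)(=O)NC(=O)Nc2ccc(Cl)cc2)s1` is not yet measured and differs from compound 2 by methoxy in place of chloro on an aromatic carbon. Among the measured compounds shown here, no measured step places a methoxy on this ring; the only step that bears on this position is a number 23 percentage points higher from compound 1 to compound 2 (beyond the scatter), which shows that a group there moves the read-out. Compound 3 is therefore expected to fall between the two measured numbers, estimated at 70% with a range of 45% to 92%, an expected step of a number 19 percentage points lower from compound 2 to compound 3 (beyond the scatter).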

Compound 3, a percentage reported as inhibition, in the whole organism at one dose (the size of the read-out at that dose, not a potency): 100%
For compound 3 the middle estimate is 30 percentage points below the measured one, and the stated range ends below it.
By their numbers in this assay, from the lowest: compound 1; then compound 2; then compound 3.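

In this assay methoxy gives a number 11 percentage points higher from compound 2 to compound 3 (beyond the scatter) and so outdoes chloro on this carbon, which shows that the rise seen with chloro is not particular to that group. Against hydrogen, methoxy gives a number 34 percentage points higher from compound 1 to compound 3 (beyond the scatter) and is the larger of the two changes from the unsubstituted thiophene. Nothing available here accounts for this order of the three groups.

As far as these compounds go, whether other groups on this carbon also raise the read-out stays open: an amine, a carboxylic acid or a longer chain such as ethoxy would test this. With one dose, the numbers give no potency ranking.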